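A third aryl group on the shared core

The source may hold more compounds than are shown below. What is called first, only, known or untested is meant among the compounds shown, and "the series" means these compounds.

Compound 1 `O=C(CCCCCN(CC(=O)NC1CCCCC1)C(=O)c1cccc2ccccc12)NO`: 4120 nM
Compound 2 `CN(C)c1ccc(C(=O)N(CCCCCC(=O)NO)CC(=O)NC2CCCCC2)cc1`: 3310 nM

Going by the values given here, in a functional assay on A2780cisR cells (Homo sapiens) for cytotoxicity, read by MTT assay, with a stated time of 72 h (on this read-out lower numbers stand for stronger inhibition and higher numbers for weaker inhibition), compound 2 gives 3310 nM and stands within the scatter of compound 1, the only other measured compound. Compound 3 `Cc1cc(C)cc(C(=O)N(CCCCCC(=O)NO)CC(=O)NC2CCCCC2)c1` carries 3,5-dimethylphenyl in place of 4-(dimethylamino)phenyl on a carbonyl carbon. Among the compounds with values here, one measured step bears on this, a swap on that same carbonyl carbon: a 1.2-fold lower number from compound 1 to compound 2 (0.10 log units; within the scatter) when 4-(dimethylamino)phenyl replaced naphthalen-1-yl. Within the data shown here, with only that small step as a guide, no change beyond the scatter is expected in this assay here. An estimated 1.1-fold higher number from compound 2 to compound 3 (0.02 log units; within the scatter) is all that is expected. Compound 3 is estimated at 3500 nM (range 1600 nM to 7500 nM).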

Compound 3, half-maximal inhibitory concentration: 3810 nM
For compound 3 the middle estimate is 1.1-fold (0.04 log units) below the measured one; measured number inside the range.
By their numbers in this assay, from the lowest: compounds 2, 3 and 1 (each within the scatter of the next).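

In this assay the third aryl group changes little: there is a 1.2-fold higher number from compound 2 to compound 3 (0.06 log units; within the scatter) and a 1.1-fold lower number from compound 1 to compound 3 (0.03 log units; within the scatter) as well. Swapping 4-(dimethylamino)phenyl for 3,5-dimethylphenyl removes the nitrogen and the hydrogen-bond acceptor from this group, yet no readable difference follows, so the three groups on this carbonyl carbon cannot be ranked. No measurement here offers an explanation for this flat result.

As far as these compounds go, it remains open whether a phenyl ring carrying a carboxylic acid or a primary amine would move the number beyond the scatter. A longer chain on the shared core also remains untested among these compounds.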